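Pyridine nitrogen position in a sulfonamide cyanoguanidine series

A few compounds are considered here, and "the series" means these few. Any claim that something is new, unique, unknown or untested is made for them only; others in the source may bear on it.

Compound 3 `N#C/N=C(\NCc1ccc(S(=O)(=O)N2CC3CCC(C2)O3)cc1)Nc1ccncc1` is one of three close analogues sharing a cyanoguanidine core. In an assay on isolated protein for inhibition of Nicotinamide phosphoribosyltransferase (Homo sapiens), read by mass spectrometry, with stated times of 15 min and 30 min (on this read-out higher numbers stand for weaker inhibition and lower numbers for stronger inhibition), compound 3 gives 2.4 nM, level with compound 2 `N#C/N=C(\NCc1ccc(S(=O)(=O)c2cccc(C(F)(F)F)c2)cc1)Nc1ccncc1` at 2.4 nM and within the scatter of compound 1 `N#C/N=C(\NCc1ccc(S(=O)(=O)c2ccccc2)cc1)Nc1cccnc1` at 2.2 nM. Among the compounds with values here, the single step recorded, no change at the digits printed from compound 2 to compound 3 (within the scatter), concerns the sulfonyl substituent and does not bear on the change now considered. Compound 4 `N#C/N=C(\NCc1ccc(S(=O)(=O)N2CC3CCC(C2)O3)cc1)Nc1cccnc1` differs from compound 3 by pyridin-3-yl in place of pyridin-4-yl on an amine nitrogen. Within the data shown here, no step isolates this swap: compound 1 and compound 2 differ at the pyridine but also at the sulfonyl group, and their values lie within the scatter of each other. Compound 4 is therefore expected to show no change beyond the scatter, a 1.0-fold lower number from compound 3 to compound 4 (0.02 log units; within the scatter), with an estimated 2.3 nM and a range from 1.1 nM to 4.8 nM.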

Compound 4, half-maximal inhibitory concentration: 4.4 nM
Compound 4: middle estimate off by 1.9-fold (0.28 log units), on the low side; measured number inside the range.
By their numbers in this assay, from the lowest: compounds 1, 2, 3 and 4 (each within the scatter of the next).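

Isolated on a single sulfonyl group in this assay, pyridin-3-yl in place of pyridin-4-yl on the amine nitrogen gives a 1.8-fold higher number from compound 3 to compound 4 (0.26 log units; within the scatter), so the two pyridine attachments are not separated by this assay. With pyridin-3-yl held fixed, exchanging the all-carbon aromatic ring on the sulfonyl sulfur for the two-ring group gives a 2.0-fold higher number from compound 1 to compound 4 (0.30 log units; within the scatter), so that exchange is not resolved either. Nothing shown offers an explanation for these numbers. Still open, from the compounds shown here alone, is whether pyridin-2-yl on the amine nitrogen would stay in this range. Also open, going by these compounds, is whether a phenyl ring there, with no ring nitrogen, would do so.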